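Furan position change in a dihydropyrimidinone series

The source may hold more compounds than are shown below. What is called first, only, known or untested is meant among the compounds shown, and "the series" means these compounds.

Compound 2 `COC(=O)C1=C(C)N(C)C(=O)NC1c1ccco1` stands second highest of the three numbers in an assay on membranes from HEK293 cells for displacement of a labelled ligand from adenosine receptor A2b (Homo sapiens), read by scintillation counting, with a stated time of 30 min, tested at 1 uM (a lower number here means less inhibition, a higher number more inhibition at the concentration tested (going by the name of the read-out)), where compound 2 gives 31%. Its nearest neighbour is compound 3 `CC1=C(C(=O)OC(C)(C)C)C(c2ccco2)NC(=O)N1C`, which gives 26%; the step of a number 5 percentage points lower from compound 2 to compound 3 (within the scatter) is within the scatter. The furthest is compound 1 `COC(=O)C1=C(C)NC(=O)NC1c1ccoc1`, which gives 42%, a gap beyond the scatter.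

The next compound, compound 4 `COC(=O)C1=C(C)N(C)C(=O)NC1c1ccoc1`, differs from compound 2 by furan-3-yl in place of furan-2-yl on a saturated ring carbon. Among the measured compounds shown here, no measured step follows this change alone. For the measured compounds named here, the one measured step, a number 5 percentage points lower from compound 2 to compound 3 (within the scatter), concerns the ester and was within the scatter, so it offers no guidance here. Going by the values given here, compound 1 carries furan-3-yl and compound 2 carries furan-2-yl, yet the two differ in more than one place, so their values show only that the furan-3-yl compound sits higher.

Because compound 1 gives 42% while compound 2 gives 31%, a small rise is expected, not clearly beyond the scatter: compound 4 is estimated at 36% (range 22% to 50%), an expected step of a number 5 percentage points higher from compound 2 to compound 4 (within the scatter).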

Compound 4, a percentage reported as inhibition, at one concentration (the size of the read-out at that concentration, not a potency): 7%
The estimate for compound 4 lay 29 percentage points above the measured number; the whole stated range lies above it.
By their numbers in this assay, from the lowest: compound 4; then compounds 3 and 2 (each within the scatter of the next); then compound 1.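

In this assay the attachment point of the furan matters on the saturated ring carbon: furan-3-yl in place of furan-2-yl gives a number 24 percentage points lower from compound 2 to compound 4 (beyond the scatter) even though both groups carry the same atoms, whereas the ester step gave no change beyond the scatter. The amide-type nitrogen in the ring also emerges as a sensitive place, with methyl in place of hydrogen giving a number 35 percentage points lower from compound 1 to compound 4 (beyond the scatter) while furan-3-yl stays fixed. No measurement shown here accounts for either step.

Still open, going by these compounds, is whether the furan position has the same effect with the amide hydrogen in place, and whether the methyl step holds with furan-2-yl. Also open, on these data alone, is how a longer chain on that nitrogen, or an amine or a carboxylic acid in place of the furan, would read in this assay.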